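A few compounds are considered here, and "the series" means these few. Any claim that something is new, unique, unknown or untested is made for them only; others in the source may bear on it.

Compound 3 `COc1ccc(S(=O)(=O)c2cnc3cc(F)ccc3c2-c2cccc(F)c2)cc1` stands second highest of the three numbers in an ADME assay on microsomes from liver (Homo sapiens) for metabolic stability, tested at 2.5 uM (on this read-out lower numbers stand for slow clearance and higher numbers for fast clearance), where compound 3 gives 2.94 mL/min. Its nearest neighbour is compound 1 `COc1cccc(S(=O)(=O)c2cnc3cc(F)ccc3c2-c2cccc(F)c2)c1`, for which compound 1 gives 3.36 mL/min; the step of a 1.1-fold lower number from compound 1 to compound 3 (0.06 log units; within the scatter). Furthest is compound 2 `COc1ccc(S(=O)(=O)c2cnc3cc(F)ccc3c2-c2cccc(F)c2)cc1Cl`, where compound 2 gives 2.08 mL/min, and the step of a 1.4-fold higher number from compound 2 to compound 3 (0.15 log units; within the scatter). Compound 4 `Cc1ccc(S(=O)(=O)c2cnc3cc(F)ccc3c2-c2cccc(F)c2)cc1F` is not yet measured; it differs from compound 3 in this way: 3-fluoro-4-methylphenyl in place of 4-methoxyphenyl on a sulfonyl sulfur. Within the data shown here, three measured steps bear on a change of the group on the sulfonyl sulfur: a 1.1-fold lower number from compound 1 to compound 3 (0.06 log units; within the scatter), a 1.4-fold higher number from compound 2 to compound 3 (0.15 log units; within the scatter) and a 1.6-fold lower number from compound 1 to compound 2 (0.21 log units; within the scatter), each within the scatter. On that basis no step beyond the scatter is expected in this assay, in either direction. Compound 4 is therefore estimated to give 2.9 mL/min, within a range from 1.4 mL/min to 5.8 mL/min. The step this expectation means, a 1.0-fold lower number from compound 3 to compound 4 (0.01 log units; within the scatter), is estimated to stay within the scatter.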

Compound 4, intrinsic clearance in a liver preparation (reported as CLH), per the amount of preparation that the assay uses: 0.41 mL/min
Compound 4: the middle estimate sits 7.1-fold (0.85 log units) above what was measured; the measured number lies below the stated range.
By their numbers in this assay, from the lowest: compound 4; then compounds 2, 3 and 1 (each within the scatter of the next).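

In this assay, the group on a sulfonyl sulfur proves able to move the read-out: 3-fluoro-4-methylphenyl in place of 4-methoxyphenyl gives a 7.2-fold lower number from compound 3 to compound 4 (0.86 log units; beyond the scatter) and the same group gives a 5.1-fold lower number from compound 2 to compound 4 (0.71 log units; beyond the scatter) as well as an 8.2-fold lower number from compound 1 to compound 4 (0.91 log units; beyond the scatter) on the same core. Among these compounds, compounds 1, 2 and 3 stay within the scatter of one another, so the swaps among the methoxy-bearing groups did not reveal this reach, and compound 4, the one compound of the four without a methoxy group, stands apart from all three. Nothing at hand explains this difference.

Going by these compounds, the step changes two features at once, so it stays open whether a 4-methylphenyl group alone or a 3-fluorophenyl group alone would give the same low number. On these data alone, how a nitrile or an amine on that ring would read out also remains open.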